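The compounds below may be only part of what the source reports. "The series", "measured", "known", "first", "only" and "open" are said of these compounds alone.

Series notes. Compound 1 `COc1cc(C(=O)Nn2ccnc2NCc2ccc(-c3cc(Cl)cc(F)c3-c3noc(C)n3)cc2F)on1` is the reference point; in a functional assay on IMR-90 cells for antagonist activity at B1 bradykinin receptor (Homo sapiens), read by calcium flux (a lower number here means a stronger inhibitor, a higher number a weaker inhibitor), compound 1 gives 1.7 nM, the lowest of the three numbers in hand. Compound 2 `COc1cc(C(=O)Nn2c(NCc3ccc(-c4cc(Cl)cc(F)c4-c4noc(C)n4)cc3F)nc(C)c2C)on1` gives 85 nM in this assay, and compound 3 `COC(=O)c1c(F)cccc1-c1ccc(CNC(C)=O)c(F)c1` gives 35000 nM. For the measured compounds named here, no single-point step links any two of these measured compounds; their values simply show compound 1 at the low end, compound 2 well above it, and compound 3 far weaker than either.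

Compound 4 `CC(=O)Nn1ccnc1NCc1ccc(-c2cc(Cl)cc(F)c2-c2noc(C)n2)cc1F` has not yet been run in this assay. It differs from compound 1 in one place: methyl in place of 3-methoxy-1,2-oxazol-5-yl on a carbonyl carbon. Read one bond further out, the (3-methoxy-1,2-oxazol-5-yl)carbonyl of compound 1 becomes an acetyl in compound 4, and the ((3-methoxy-1,2-oxazol-5-yl)carbonyl)amino becomes an acetamido. Going by the values given here, compound 3 also carries an acetamido and gives 35000 nM, but it shares little else with compound 1, so no step can be drawn from it. With no measured step of this kind in the set, the size of the change is uncertain; a loss of potency beyond the scatter is expected. The estimate for compound 4 is 50 nM, with a range of 8 nM to 400 nM. The expected step in this assay is a 29-fold higher number from compound 1 to compound 4 (1.47 log units; beyond the scatter).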

Compound 4, half-maximal inhibitory concentration: 1.6 nM
Compound 4: the middle estimate sits 31-fold (1.49 log units) above what was measured; measured number outside the range, below it.
By their numbers in this assay, from the lowest: compounds 4 and 1 (each within the scatter of the next); then compound 2; then compound 3.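

In this assay, exchanging 3-methoxy-1,2-oxazol-5-yl for methyl on the carbonyl carbon gives a 1.1-fold lower number from compound 1 to compound 4 (0.03 log units; within the scatter), so this position takes a very large change in group with no readable change in the number. The five-membered aromatic ring and its methoxy group, with all the hydrogen-bond acceptors counted for that group, can leave this position without a measurable cost in this pair, and the smaller acetamido serves as well as the larger ((3-methoxy-1,2-oxazol-5-yl)carbonyl)amino. No measurement in hand bears on why the number holds across this exchange.

With only methyl and 3-methoxy-1,2-oxazol-5-yl shown on this carbonyl carbon, it remains open whether a longer chain such as propyl, a basic group such as a dimethylamino-bearing chain, or a carboxylic acid would also leave the number in place. As far as these compounds go, it also remains open whether the carbonyl itself is needed, which a plain amino group in place of the acetamido of compound 4 would test.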